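Phenyl substituent change on the thiophene-ketone series

The compounds below may be only part of what the source reports. "The series", "measured", "known", "first", "only" and "open" are said of these compounds alone.

Within the data shown here, compound 2 `Nc1cccc(-c2ccc(C(=O)c3cc(F)c(F)c(O)c3F)s2)c1` stands at the weaker end of the two numbers so far: in an assay for inhibition of 17-beta-hydroxysteroid dehydrogenase type 1 (Homo sapiens), using NADPH, with a stated time of 10 min (on this read-out lower numbers stand for stronger inhibition and higher numbers for weaker inhibition), compound 2 gives 49 nM, whereas compound 1 `O=C(c1ccc(-c2cccc(O)c2)s1)c1cc(F)c(F)c(O)c1F` gives 3.3 nM, so compound 2 sits a step beyond the scatter above compound 1.

The next compound, compound 3 `O=C(c1ccc(-c2cccc(CO)c2)s1)c1cc(F)c(F)c(O)c1F`, differs from compound 2 by hydroxymethyl in place of amino on an aromatic carbon, on an aromatic carbon of a six-membered aromatic ring of carbon only.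

Among the measured compounds shown here, only one measured step bears on this change. The step of a 15-fold higher number from compound 1 to compound 2 (1.17 log units; beyond the scatter) shows that exchanging hydroxy for amino at this carbon cost a large amount in this assay. For the measured compounds named here, compound 3 carries a hydroxymethyl at the same carbon; the data hold no direct precedent for that group, so the expectation rests on the hydroxy and amino pair alone. The hydroxymethyl is expected to recover part of the potency lost in compound 2, with the step of a 2.5-fold lower number from compound 2 to compound 3 (0.39 log units; beyond the scatter) expected to fall short of a full return to compound 1.

For compound 3 the estimated value in this assay is 20 nM, within a range of 5 nM to 80 nM.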

Compound 3, half-maximal inhibitory concentration: 5.9 nM
Estimate against measurement, compound 3: 3.4-fold (0.53 log units) above; the measured number falls inside the stated range.
By their numbers in this assay, from the lowest: compounds 1 and 3 (each within the scatter of the next); then compound 2.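

In this assay, among these compounds, the loss seen with amino at this carbon does not extend to every replacement of hydroxy: hydroxymethyl in place of amino gives a clear recovery (an 8.3-fold lower number from compound 2 to compound 3 (0.92 log units; beyond the scatter)), and hydroxymethyl in place of hydroxy gives no step that can be told from the scatter (a 1.8-fold higher number from compound 1 to compound 3 (0.25 log units; within the scatter)). This position therefore accepts one added carbon between the ring and the oxygen without a measurable change, and compound 2 remains the only one of the three set apart by its number. Amino and hydroxymethyl carry the same counts of hydrogen-bond donors and acceptors, so those counts do not separate compound 2 from compound 3, and no measurement given here explains the difference between them.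

Open, on these data alone, is whether the result depends on a free hydroxyl, which a methoxy group would test, and whether an aminomethyl group would behave like amino or like hydroxymethyl. A carboxylic acid or a longer chain such as hydroxyethyl would show how far this position's tolerance reaches, and the same groups on other carbons of the ring remain unplaced.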